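The source may hold more compounds than are shown below. What is called first, only, known or untested is meant among the compounds shown, and "the series" means these compounds.

The compounds measured so far in an assay on L1.2 cells for binding affinity to C-C chemokine receptor type 8 (Homo sapiens); on this read-out lower numbers stand for stronger inhibition and higher numbers for weaker inhibition:

Compound 1, `Cc1ccccc1C(=O)Nc1ccc(S(=O)(=O)NC2CCN(C(=O)CN)CC2)c2ccccc12`: 4.1 nM
Compound 2, `Cc1ccccc1C(=O)Nc1ccc(S(=O)(=O)NC2CCN(C(=O)N(C)C)CC2)c2ccccc12`: 1.6 nM

Compound 2 holds the lower of the two numbers in this assay; its nearest neighbour is compound 1, and the gap is given by a 2.6-fold lower number from compound 1 to compound 2 (0.41 log units; beyond the scatter), a modest step beyond the scatter that comes from dimethylamino in place of aminomethyl on a carbonyl carbon.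

The next compound, compound 3, `Cc1ccccc1C(=O)Nc1ccc(S(=O)(=O)NC2CCN(C(=O)N3CCCC3)CC2)c2ccccc12`, differs from compound 2 by pyrrolidin-1-yl in place of dimethylamino on a carbonyl carbon. For the measured compounds named here, the only measured step that bears on this position is the one from compound 1 to compound 2, which was modest. That step removed a donor-bearing group; the present change keeps a group with no donors and no acceptors and merely closes it into a five-membered ring. On that basis compound 3 is expected to stay close to compound 2, with no step beyond the scatter, which is what a 1.1-fold higher number from compound 2 to compound 3 (0.03 log units; within the scatter) expresses. Compound 3 is therefore estimated at 1.7 nM in this assay, within a range from 0.7 nM to 4 nM.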

Compound 3, inhibition constant: 1.1 nM
Estimate against measurement, compound 3: 1.5-fold (0.19 log units) above; measured number inside the range.
By their numbers in this assay, from the lowest: compounds 3 and 2 (each within the scatter of the next); then compound 1.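

In this assay, replacing dimethylamino with pyrrolidin-1-yl on the carbonyl carbon gives a 1.5-fold lower number from compound 2 to compound 3 (0.16 log units; within the scatter) and so adds a five-membered non-aromatic ring and more heavy atoms without a difference that can be told from the scatter. Measured against the aminomethyl group of compound 1, the same ring gives a 3.7-fold lower number from compound 1 to compound 3 (0.57 log units; beyond the scatter) and this modest gap lies beyond the scatter, so the separation from compound 1 seen with dimethylamino in compound 2 now also appears with a second group that has no hydrogen-bond donors. No measurement is available that would explain either step.

The compounds shown leave open whether a six-membered group such as piperidin-1-yl or morpholin-4-yl, or a group on the same carbonyl carbon with a free amine on a longer chain, such as aminoethyl, would stay with compound 2 and compound 3 or fall nearer to compound 1. For the compounds shown here, they also vary only this one group on the shared core, so it remains open whether the gap between pyrrolidin-1-yl and aminomethyl would persist with other groups elsewhere on that core.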